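The source may hold more compounds than are shown below. What is called first, only, known or untested is meant among the compounds shown, and "the series" means these compounds.

Measured in a functional assay on MCF7 cells (Homo sapiens) for antiproliferative activity, read by CCK-8 assay and cell counting, with a stated time of 72 h; a higher number here means a weaker inhibitor, a lower number a stronger inhibitor:
Compound 1 `O=C(Nc1ccccc1OC(=O)c1cccc(CO[N+](=O)[O-])c1)c1cccc(CO[N+](=O)[O-])c1`: > 100000 nM (a limit)
Compound 2 `O=C(Nc1cccc(OC(=O)c2ccc(CO[N+](=O)[O-])cc2)c1)c1ccc(CO[N+](=O)[O-])cc1`: > 100000 nM (a limit)
Compound 3 `O=C(Nc1ccccc1)c1ccc(CCl)cc1`: 54300 nM

Compound 3 is the only one of the three with an actual number in this assay, since the other two readings are limits of the assay and not numbers. Its reading of 54300 nM is therefore the sole quantitative anchor, and it cannot be ranked by a measured step against either neighbour.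

Compound 4 `O=C(Nc1ccccc1)c1ccc(CO[N+](=O)[O-])cc1` has not yet been measured. It keeps the framework of compound 3, with nitrooxy in place of chloro on a saturated chain carbon bound to an aromatic carbon. Within the data shown here, no measured pair isolates this change, so any expectation is tentative.

The only hints come from the two other compounds that carry nitrooxy. Compound 1 gives only the limit > 100000 nM. Compound 2 likewise gives only the limit > 100000 nM. Both differ from compound 4 in much more than this group, so they are weak guides. A modest estimated step of a 1.3-fold higher number from compound 3 to compound 4 (0.11 log units; within the scatter) is expected, towards weaker inhibition, and it may not exceed the scatter. A reading at the limit of the assay would not be surprising. For compound 4 the estimate is 70000 nM, with an expected range of 30000 nM to 100000 nM.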

Compound 4, half-maximal inhibitory concentration: > 100000 nM
Compound 4: only a limit was reported; the forecaster's own chance of this, stated with the estimate: 45%; at least 1.4-fold (0.15 log units) between middle value and limit.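

This pair is the first among the compounds shown to differ in one place, so nitrooxy in place of chloro on a saturated chain carbon bound to an aromatic carbon can now be read on its own in this assay (an at least 1.8-fold higher number from compound 3 to compound 4 (0.26 log units; that floor lies within the scatter)). Compound 4 gives > 100000 nM, which is a limit of the assay and not a number. On the shared core, then, this change gives no sign of stronger inhibition, while its full size remains unmeasured, as the reading stops at the same ceiling as the other nitrooxy compounds: the limit of > 100000 nM in this assay, at which 3 of the 4 values shown sit.

The compounds shown leave open whether the true step from chloro to nitrooxy lies beyond the scatter or only reaches its edge. Among these compounds, they also leave open whether another group on this carbon, such as an amine, a carboxylic acid or a longer chain, would give a measured number in this assay and how that number would compare with the one for compound 3.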